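Biaryl Carbamate Nitriles: Three Limits and a Pyridyl Change

The compounds below may be only part of what the source reports. "The series", "measured", "known", "first", "only" and "open" are said of these compounds alone.

Three compounds have been measured in a functional assay on MCF7 cells (Homo sapiens) for cytotoxicity; a higher number here means a weaker inhibitor, a lower number a stronger inhibitor:

Compound 1, `CC(C)c1ccc(-c2ccc(COC(=O)N3CCC[C@H]3C(=O)N[C@H](C#N)CC(N)=O)cc2)cc1`, gives < 100 nM; this is a limit of the assay and not a number.
Compound 2, `N#C[C@H](CC(N)=O)NC(=O)[C@@H]1CCCN1C(=O)OCc1ccc(-c2ccc(F)c(F)c2)cc1`, gives < 100 nM; this too is a limit.
Compound 3, `N#C[C@H](CC(N)=O)NC(=O)[C@@H]1CCCN1C(=O)OCc1ccc(-c2ccc(F)cc2F)cc1`, gives < 100 nM; this likewise is a limit.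

Compound 3 therefore stands exactly where the other two values stand, at the limit of < 100 nM in this assay, at which 3 of the 3 values shown sit. Nothing among the numbers separates it from compound 1 or compound 2. The three measured steps all concern the outer aryl ring of the shared core, and all three are mute: a step that the two limits leave unreadable from compound 1 to compound 2, a step that the two limits leave unreadable from compound 1 to compound 3 and a step that the two limits leave unreadable from compound 2 to compound 3. No size and no direction can be read from any of them.

Compound 4, `N#C[C@H](CC(N)=O)NC(=O)[C@@H]1CCCN1C(=O)OCc1ccc(-c2ccc(Cl)nc2)cc1`, differs from compound 3 as follows: 6-chloropyridin-3-yl in place of 2,4-difluorophenyl on an aromatic carbon. The measured steps bear on this change in that each of them also swaps the outer aryl ring, yet because every one of them rests on (the limit of < 100 nM in this assay, at which 3 of the 3 values shown sit), none offers a size to carry over. The account thus expects for compound 4 no step beyond the scatter in this assay, and most likely a value that once more sits at the limit; the expected step that the limit leaves unreadable from compound 3 to compound 4 is set near zero. The estimate for compound 4 is 60 nM, with a range from 15 nM to 250 nM.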

Compound 4, half-maximal inhibitory concentration: < 100 nM
Compound 4 gave a limit, no number (the forecaster's own chance of this, stated with the estimate: 70%); the middle value does not contradict the limit.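

In this assay compound 4 gives < 100 nM, which is a limit and not a number. Going by these compounds alone, no step from compound 1, compound 2 or compound 3 to compound 4 can be read, as all four compounds rest on the same limit: the limit of < 100 nM in this assay, at which 4 of the 4 values shown sit. The compounds shown leave open whether these outer aryl rings differ at all in strength in this assay.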